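Extending One Chain from Ethyl to Isobutyl

The compounds below may be only part of what the source reports. "The series", "measured", "known", "first", "only" and "open" are said of these compounds alone.

Compound 1 `CCNC(=O)c1cc(C(=O)NC)c(=O)n(Cc2ccccc2)c1`: >= 144 ug/mL
Compound 2 `CNC(=O)c1cc(C(=O)NC2CC2)cn(CC2CCCCC2)c1=O`: >= 148 ug/mL
Compound 3 `CNC(=O)c1cc(C(=O)NC2CC2)cn(Cc2cccc3[nH]c(C)nc23)c1=O`: >= 198 ug/mL

In a physicochemical assay for solubility (on this read-out higher numbers stand for higher solubility and lower numbers for lower solubility), compound 1 gives >= 144 ug/mL, which is a limit and not an exact number. Within the data shown here, the readings for compound 2 and compound 3 are limits too, so no compound here has an exact value to compare.

Compound 4 `CNC(=O)c1cc(C(=O)NCC(C)C)cn(Cc2ccccc2)c1=O` keeps the core of compound 1 and differs in one place: isopropyl in place of methyl on a saturated chain carbon bound to an amide-type nitrogen. In words, this is isopropyl in place of methyl on a saturated chain carbon bound to an amide-type nitrogen.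

Among the measured compounds shown here, no two measured compounds differ in only one place, so the data offer no direct guide to the size of this step. A modest downward move in this assay is expected, close to the usual scatter, and the estimated step is an at least 1.0-fold lower number from compound 1 to compound 4 (0.01 log units; that floor lies within the scatter). Compound 4 is estimated at 140 ug/mL, with an expected range of 70 ug/mL to 175 ug/mL.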

Compound 4, solubility: 43 ug/mL
The estimate for compound 4 lay 3.3-fold (0.51 log units) above the measured number; measured number outside the range, below it.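

The change from ethyl to isobutyl on the amide chain comes with an at least 3.3-fold lower number from compound 1 to compound 4 (0.52 log units; beyond the scatter) in this assay, and the true drop may be larger, because the starting point is only a limit: the limit of >= 144 ug/mL in this assay, at which 1 of the 4 values shown sits. Compound 4 is the only compound shown with an exact number, so this is the first change in the set whose direction can be read at all. The step lies beyond the usual scatter, so this chain position is not indifferent to the change.

Compound 2 and compound 3 differ from compound 1 in more than one place, so they say nothing about this chain. On these data alone, whether the drop follows the added length or the branching stays open, and a straight propyl chain, a longer chain or a chain ending in an amine on the same core would help to separate these.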